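The source may report more compounds than this note shows. Statements on the series, on what has been measured and on what is new or still open speak of the compounds shown alone.

Three compounds of one shared core carry a chloromethyl-substituted benzyl arm: compound 1 `ClCc1cccc(Cn2cnc3c(Cl)nc(Cl)nc32)c1`, compound 2 `ClCc1ccccc1Cn1cnc2c(Cl)ncnc21` and compound 3 `ClCc1ccc(Cn2cnc3ncnc(Cl)c32)cc1`. In a functional assay on NCI-H322M cells (Homo sapiens) for cytotoxicity, read by sulforhodamine B assay, with a stated time of 48 h (on this read-out higher numbers stand for weaker inhibition of growth and lower numbers for stronger inhibition of growth), compound 3 gives 1620 nM, and compound 1 gives 2290 nM, a gap within the usual scatter. Compound 2, in this assay, gives 3980 nM, a higher number beyond the scatter. Compound 4 `ClCc1ccc(Cn2cnc3nc(Cl)nc(Cl)c32)cc1` has not yet been measured; it differs from compound 3 by one change: chloro in place of hydrogen on an aromatic carbon. Among the compounds with values here, no measured pair shows this exact change, so the expected step from compound 3 to compound 4 is taken as small, with no direction beyond the scatter: a 1.2-fold higher number from compound 3 to compound 4 (0.09 log units; within the scatter). Compound 4 is therefore estimated at 2000 nM, with a range from 900 nM to 4500 nM.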

Compound 4, concentration for 50% growth inhibition: 670 nM
For compound 4 the middle estimate is 3.0-fold (0.47 log units) above the measured one; the measured number lies below the stated range.
By their numbers in this assay, from the lowest: compound 4; then compounds 3, 1 and 2 (each within the scatter of the next, the first and the last beyond it).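

In this assay, within the data shown here, chloro in place of hydrogen on the aromatic carbon between two ring nitrogen atoms gives a 2.4-fold lower number from compound 3 to compound 4 (0.38 log units; beyond the scatter), the first step here that isolates one single change. This position is therefore not silent: one added chlorine moves the number beyond the usual scatter, towards stronger inhibition of growth. Nothing available explains why this happens.

On these data alone, whether an amine, a methoxy group or a longer chain at this carbon would move the number the same way remains open. Also open, as far as these compounds go, is whether chloro here has the same effect when the chloromethyl group sits elsewhere on the benzyl arm.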